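The source may hold more compounds than are shown below. What is called first, only, known or untested is meant among the compounds shown, and "the series" means these compounds.

Cells can be harmed by a compound at some concentration, and in an ADME assay on Vero cells (Chlorocebus sabaeus) for cytotoxicity, read by crystal violet staining (on this read-out lower numbers stand for higher toxicity in this test and higher numbers for lower toxicity in this test), three compounds have numbers so far. Here compound 1 (`COc1ccc(/N=N/N2CCCC2)cc1`) gives 90000 nM and sits at the less toxic end of this small set. Compound 3 (`Brc1cccc(/N=N/N2CCCCC2)c1`) gives 85000 nM and cannot be told apart from compound 1 within the usual scatter. Compound 2 (`CN(C)CCCN(/N=N/c1ccccc1)c1cccc(C(F)(F)F)c1`) gives 20000 nM and is clearly more toxic than compound 1 by a margin beyond that scatter.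

Compound 4 (`Clc1ccc(/N=N/N2CCCC2)cc1`) has yet to be measured. It keeps the core of compound 1 and has chloro in place of methoxy on an aromatic carbon. For the measured compounds named here, no measured pair shows this exchange, so there is no direct guide to its size. The nearest hint is compound 3, which also carries a halogen and gives 85000 nM on a different framework. In this assay the expectation is therefore a small step, perhaps slightly towards higher toxicity, and none beyond the scatter. The estimated change is a 1.3-fold lower number from compound 1 to compound 4 (0.11 log units; within the scatter) and remains a forecast. For compound 4 the expected value is 70000 nM with an estimated range from 30000 nM to 150000 nM until the measurement arrives.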

Compound 4, half-maximal cytotoxic concentration: > 100000 nM
Compound 4 was reported as a limit; the forecaster's own chance of this, stated with the estimate: 10%; at least 1.4-fold (0.15 log units) between middle value and limit.
By their numbers in this assay, from the lowest: compound 2; then compounds 3 and 1 (each within the scatter of the next). At a limit, above all of these: compound 4.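

In this assay compound 4 gives > 100000 nM, which is a limit of the assay and not a number. For the compounds shown here, with the core of compound 1 left unchanged, this is the first direct view of chloro in place of methoxy on an aromatic carbon, and it reads as an at least 1.1-fold higher number from compound 1 to compound 4 (0.04 log units; that floor lies within the scatter). At this position, the exchange shows no sign of a lower number and so no sign of higher toxicity in this test, but only a floor can be stated, that floor lies within the scatter, and the true size of the step remains unknown: the limit of > 100000 nM in this assay, at which 1 of the 4 values shown sits.

The compounds shown do not reveal how far cell tolerance at this position depends on the group placed there, for example whether an amine, a carboxylic acid or a longer chain in place of chloro would keep the number at the limit or bring it down. Going by these compounds alone, they also leave open whether chloro in place of methoxy would give a similar result on a different core, since this exchange is seen in only one pair of compounds.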